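Removing a bromine from an already inactive pair

The source may hold more compounds than are shown below. What is called first, only, known or untested is meant among the compounds shown, and "the series" means these compounds.

Compound 1 `Clc1ccc(-c2cn3nc(Cl)sc3n2)cc1` gives > 250000 nM in an ADME assay on CCRF-CEM cells (Homo sapiens) for cytotoxicity, with a stated time of 72 h (on this read-out lower numbers stand for stronger inhibition and higher numbers for weaker inhibition), a limit of the assay rather than a number.
Compound 2 `Clc1ccc(Cc2nn3cc(-c4ccc(Br)cc4)nc3s2)cc1` gives > 250000 nM in this assay, likewise a limit.

Compound 2 thus stands at the limit, and the limit of > 250000 nM in this assay, at which 2 of the 2 values shown sit, shows that both recorded values sit there. Compound 3 `Clc1ccc(Cc2nn3cc(-c4ccccc4)nc3s2)cc1` differs from compound 2 by hydrogen in place of bromo on an aromatic carbon. For the measured compounds named here, no step between measured compounds is available, so no direction can be read; the expectation is no change beyond the scatter. In this assay compound 3 is expected to give 250000 nM (range 100000 nM to 600000 nM). That corresponds to an expected step of a number no higher from compound 2 to compound 3 (the limit leaves the size open), most likely reported again only as a limit.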

Compound 3, half-maximal inhibitory concentration: > 250000 nM
Compound 3: only a limit was reported; the forecaster's own chance of this, stated with the estimate: 80%; the middle value sits exactly at the limit.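

No new step can be read from compound 2 to compound 3, since both are reported only as limits: the limit of > 250000 nM in this assay, at which 3 of the 3 values shown sit. The compounds shown leave open whether swapping bromo for hydrogen changes anything in this assay.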